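The source may report more compounds than this note shows. Statements on the series, on what has been measured and on what is new or still open speak of the compounds shown alone.

Working notes on the series

Of the compounds shown here, three of the shared core have been measured in a functional assay on 786-0 cells (Homo sapiens) for inhibition, read by sulforhodamine B assay, with a stated time of 48 h; a lower number here means a stronger inhibitor of growth, a higher number a weaker inhibitor of growth. Compound 1 `CCOC(=O)C1=C(C)NC(=O)NC1c1ccc(O)cc1` gives 25.8 ug/mL. Compound 2 `CCOC(=O)C1=C(C)NC(=S)NC1c1ccc(OC)cc1` gives 25.9 ug/mL, the highest of the three numbers, and it sits within the scatter of compound 1. Compound 3 `CCOC(=O)C1=C(C)NC(=S)NC1C1CCCCC1` gives 4.2 ug/mL, and the gap between compound 2 and compound 3 lies beyond the scatter.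

Compound 4 `CCCc1ccc(C2NC(=S)NC(C)=C2C(=O)OCC)cc1` is not yet measured in this assay. It differs from compound 2 in one place: propyl in place of methoxy on an aromatic carbon. Going by the values given here, no measured pair carries this change, so its size is not known. A small step toward a lower number is expected, a 1.7-fold lower number from compound 2 to compound 4 (0.24 log units; within the scatter), of a size that may still fall within the scatter. Compound 4 is estimated at 15 ug/mL, with a range from 5 ug/mL to 40 ug/mL.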

Compound 4, concentration for 50% growth inhibition: 27.7 ug/mL
For compound 4 the middle estimate is 1.8-fold (0.27 log units) below the measured one; the measured number falls inside the stated range.
By their numbers in this assay, from the lowest: compound 3; then compounds 1, 2 and 4 (each within the scatter of the next).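

In this assay, propyl in place of methoxy on the aromatic carbon gives a 1.1-fold higher number from compound 2 to compound 4 (0.03 log units; within the scatter), the first step read at this position. At this place, para to a large group, an oxygen-free chain with no hydrogen-bond acceptor therefore leaves the number within the scatter of the methoxy compound. No measurement at hand gives a cause for this result.

Going by these compounds, whether an amine or a carboxylic acid on this aromatic carbon would give a number beyond the scatter of compound 2 remains open. The same holds for a longer chain.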